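A few compounds are considered here, and "the series" means these few. Any claim that something is new, unique, unknown or untested is made for them only; others in the source may bear on it.

Two coumarin-type compounds from this series have numbers in an assay on isolated protein for inhibition of Amine oxidase [flavin-containing] B (Homo sapiens), read by fluorescence; on this read-out higher numbers stand for weaker inhibition and lower numbers for stronger inhibition. Compound 1 `COc1cc(Br)cc2cc(-c3ccccc3)c(=O)oc12` gives 83.5 nM, the highest of the two values. Compound 2 `COc1ccc(-c2cc3cc(Br)cc(OC)c3oc2=O)cc1` gives 1.35 nM; the step is a 62-fold lower number from compound 1 to compound 2 (1.79 log units; beyond the scatter), a methoxy in place of hydrogen on an aromatic carbon. Compound 3 `O=c1oc2c(O)cc(Br)cc2cc1-c1ccccc1` is not yet measured; it differs from compound 1 by hydrogen in place of methyl on an oxygen on an aromatic ring. No measured step touches the oxygen on the aromatic ring, so the one step shown does not bear on this change. For compound 3 the expectation is a number close to that of compound 1, a step of a 1.0-fold higher number from compound 1 to compound 3 (0.01 log units; within the scatter) not beyond the scatter, estimated at 85 nM with a range from 25 nM to 300 nM.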

Compound 3, half-maximal inhibitory concentration: 30900 nM
The estimate for compound 3 lay 360-fold (2.56 log units) below the measured number; the measured number lies above the stated range.
By their numbers in this assay, from the lowest: compound 2; then compound 1; then compound 3.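

The methyl on this oxygen matters: methoxy to hydroxy gives a 370-fold higher number from compound 1 to compound 3 (2.57 log units; beyond the scatter), so this position tolerates the change poorly, which the earlier step at another place on the core could not show. Evidence on what lies behind this step is lacking.

Open, as far as these compounds go, is whether a longer chain such as ethoxy, or an amine in place of the methoxy, would keep the inhibition of compound 1. Also open, from the compounds shown here alone, is whether the same change costs as much on the core of compound 2, which carries the second methoxy.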